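Trimethylsilyl in place of a sulfonamide on the triazole

The source may hold more compounds than are shown below. What is called first, only, known or untested is meant among the compounds shown, and "the series" means these compounds.

Measured so far:
compound 1, `COc1ccc(-c2cn(C/C=C3\OC(=O)C(OCc4ccccc4)=C3OCc3ccccc3)nn2)cc1`: > 100000 nM
compound 2, `Cc1ccc(S(=O)(=O)NCc2cn(C[C@H](O)[C@H]3OC(=O)C(OCc4ccccc4)=C3OCc3ccccc3)nn2)cc1`: 68000 nM
compound 3, `O=C1O[C@H]([C@@H](O)Cn2cc(CNS(=O)(=O)c3ccc(Cl)cc3F)nn2)C(OCc2ccccc2)=C1OCc1ccccc1`: 58200 nM

The three compounds share a core and were tested in a functional assay on CFPAC-1 cells (Homo sapiens) for antiproliferative activity, read by MTT assay, with a stated time of 72 h; a lower number here means a stronger inhibitor, a higher number a weaker inhibitor. Compound 1 returned only a limit of > 100000 nM, a limit of the assay and not a number (the limit of > 100000 nM in this assay, at which 1 of the 3 values shown sits). Compound 2 gave 68000 nM. Compound 3 gave 58200 nM. Among the two numbers, compound 2 stands highest, and the only measured step, a 1.2-fold lower number from compound 2 to compound 3 (0.07 log units; within the scatter), lies within the scatter.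

Compound 4, `C[Si](C)(C)c1cn(C[C@H](O)[C@H]2OC(=O)C(OCc3ccccc3)=C2OCc2ccccc2)nn1`, is not yet measured. It differs from compound 2 in one place: a group of 4 heavy atoms (3 carbon, 1 silicon; no ring) in place of a group of 12 heavy atoms (8 carbon, 1 nitrogen, 2 oxygen, 1 sulfur; one six-membered aromatic ring of carbon only), on an aromatic carbon. Among the compounds with values here, no measured step touches this part of the molecule; the one step known changes the aryl on the sulfonyl sulfur and was within the scatter. There is therefore nothing in the data to anchor a direction, and the expectation for compound 4 is a step of no more than the scatter, a 1.0-fold higher number from compound 2 to compound 4 (0.01 log units; within the scatter), with a wide range. Compound 4 is thus estimated at 70000 nM, expected between 25000 nM and 200000 nM.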

Compound 4, half-maximal inhibitory concentration: 52600 nM
Compound 4: the middle estimate sits 1.3-fold (0.12 log units) above what was measured; the measured number falls inside the stated range.
By their numbers in this assay, from the lowest: compounds 4, 3 and 2 (each within the scatter of the next). At a limit, above all of these: compound 1.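

In this assay, the exchange of the (((4-methylphenyl)sulfonyl)amino)methyl group for trimethylsilyl on this aromatic carbon gives a 1.3-fold lower number from compound 2 to compound 4 (0.11 log units; within the scatter). The earlier step altered only the aryl on the sulfonyl sulfur, whereas this one removes the whole sulfonamide side chain with its aromatic ring and its hydrogen-bond donor, and the two values still lie within the scatter of each other, so at this level of activity the number does not depend on that side chain. Nothing measured here offers a cause for this result.

From the compounds shown here alone, it remains open whether an amine, a carboxylic acid or a longer alkyl chain at this position would move the number beyond the scatter. The compounds shown also leave open what a free hydroxyl in place of either benzyl ether on the shared core would do.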